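The source may report more compounds than this note shows. Statements on the series, on what has been measured and on what is new or still open speak of the compounds shown alone.

Measured so far in an assay on MDA-MB-231 cells for binding affinity to C-X-C chemokine receptor type 4 (Homo sapiens), read by immunofluorescence and microscopy, with stated times of 10 min and 30 min; a lower number here means that less compound is needed, a higher number that more compound is needed for the effect:
compound 1 `O=C(NCc1ccc(CNS(=O)(=O)c2ccccc2)cc1)c1cccnc1` — 10 nM
compound 2 `O=C(NCc1ccc(CNS(=O)(=O)c2ccccc2)cc1)c1c(Cl)cc(Cl)cc1Cl` — 10 nM
compound 3 `Cc1cccc(C(=O)NCc2ccc(CNS(=O)(=O)c3ccccc3)cc2)c1` — 1000 nM

Compound 3 stands highest of the three numbers. The step of a 100-fold higher number from compound 1 to compound 3 (2.00 log units; beyond the scatter) and the step of a 100-fold higher number from compound 2 to compound 3 (2.00 log units; beyond the scatter) both lead up to it, whereas no change at the digits printed from compound 1 to compound 2 (within the scatter) shows that pyridin-3-yl and 2,4,6-trichlorophenyl on the carbonyl carbon give results within the scatter of each other. Compound 4 `O=C(NCc1ccc(CNS(=O)(=O)c2ccccc2)cc1)c1ccccc1Cl` has not been measured. The change is 2-chlorophenyl in place of 3-methylphenyl on a carbonyl carbon. The two steps onto compound 3 bear on this one: each is large, and each exchanges the group on the carbonyl carbon while the rest of the shared core stays fixed. Compound 2, whose ring on the carbonyl carbon also carries chlorine, gives 10 nM. The expectation is therefore a move back toward the numbers of compounds 1 and 2, a lower number beyond the scatter, its size uncertain because a 100-fold higher number from compound 2 to compound 3 (2.00 log units; beyond the scatter) rests on a single pair. For compound 4 the expected step is a 33-fold lower number from compound 3 to compound 4 (1.52 log units; beyond the scatter). Compound 4 is estimated at 30 nM in this assay, with a range from 8 nM to 250 nM.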

Compound 4, effective concentration (reported as EC, without a stated level of effect): 10 nM
The estimate for compound 4 lay 3.0-fold (0.48 log units) above the measured number; low and high end bracket the measured number.
By their numbers in this assay, from the lowest: compounds 1, 2 and 4 (each within the scatter of the next); then compound 3.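

In this assay, a 100-fold lower number from compound 3 to compound 4 (2.00 log units; beyond the scatter) when 2-chlorophenyl replaces 3-methylphenyl on the carbonyl carbon, so this single exchange, with the count of heavy atoms unchanged, separates the two levels seen in the series. Alongside no change at the digits printed from compound 2 to compound 4 (within the scatter) and no change at the digits printed from compound 1 to compound 4 (within the scatter), this places pyridin-3-yl, 2,4,6-trichlorophenyl and 2-chlorophenyl together, leaving compound 3 as the only one of the four apart from the others, and shows that one chlorine on the ring is enough to match compound 2. Nothing at hand explains the gap between compound 3 and compound 4.

As far as these compounds go, whether the high number of compound 3 follows the methyl group or its ring position remains open, and 3-chlorophenyl or 2-methylphenyl would separate the two. Also open, from the compounds shown here alone, is how a ring carrying an amine or a carboxylic acid, or a longer chain on the carbonyl carbon, would read in this assay.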